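The compounds below may be only part of what the source reports. "The series", "measured", "known", "first", "only" and "open" are said of these compounds alone.

Of the compounds shown here, three built on one shared core have been tested in an assay for binding affinity to metabotropic glutamate receptor 5 (Rattus norvegicus); a lower number here means a stronger inhibitor, a higher number a weaker inhibitor. Compound 1 `Fc1cc(-c2ccccn2)cc(-n2nnc(-c3ccccn3)n2)c1` gives 95 nM. Compound 2 `Cc1cccnc1-c1cc(F)cc(-n2nnc(-c3ccccn3)n2)c1` gives 24 nM, and compound 3 `Cc1ccncc1-c1cc(F)cc(-n2nnc(-c3ccccn3)n2)c1` gives 2 nM. Compound 3 therefore stands with the lowest number of the three: compound 2 comes nearest, as shown by a 12-fold lower number from compound 2 to compound 3 (1.08 log units; beyond the scatter), while compound 1 lies furthest, as shown by a 48-fold lower number from compound 1 to compound 3 (1.68 log units; beyond the scatter).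

Compound 4 `Nc1cccnc1-c1cc(F)cc(-n2nnc(-c3ccccn3)n2)c1` has not yet been measured. It differs from compound 3 in one place: 3-aminopyridin-2-yl in place of 4-methylpyridin-3-yl on an aromatic carbon. The group that enters is attached through its pyridin-2-yl position, as is the 3-methylpyridin-2-yl of compound 2, so the most relevant measured steps are the large 12-fold lower number from compound 2 to compound 3 (1.08 log units; beyond the scatter) and the modest 4.0-fold lower number from compound 1 to compound 2 (0.60 log units; beyond the scatter). The first shows that exchanging the 3-methylpyridin-2-yl for the 4-methylpyridin-3-yl brought a large gain; undoing that pattern is expected to cost much of it. Whether an amino group in place of the methyl helps or hurts cannot be told from these three compounds.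

Compound 4 is therefore expected to land near compound 2, with the step of a 20-fold higher number from compound 3 to compound 4 (1.30 log units; beyond the scatter) going to a higher number. The estimated value of compound 4 in this assay is 40 nM, with a likely range from 10 nM to 160 nM.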

Compound 4, inhibition constant: 31 nM
Estimate against measurement, compound 4: 1.3-fold (0.11 log units) above; low and high end bracket the measured number.
By their numbers in this assay, from the lowest: compound 3; then compounds 2 and 4 (each within the scatter of the next); then compound 1.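

Among these compounds, the new result separates two questions that the earlier compounds left tied together: what the group on the pyridin-2-yl ring does, and how the ring itself is attached. In this assay there is a 1.3-fold higher number from compound 2 to compound 4 (0.11 log units; within the scatter), so amino and methyl cannot be told apart on this carbon, even though both give a lower number than hydrogen: amino shows a 3.1-fold lower number from compound 1 to compound 4 (0.49 log units; beyond the scatter) and methyl shows a 4.0-fold lower number from compound 1 to compound 2 (0.60 log units; beyond the scatter). The large gap to the 4-methylpyridin-3-yl group also survives the change of group, with a 16-fold higher number from compound 3 to compound 4 (1.19 log units; beyond the scatter), so with either amino or methyl the pyridin-2-yl compounds stay well short of compound 3.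

Nothing available here explains why these numbers fall as they do. Going by these compounds, it remains open whether a methoxy group or a chlorine on the pyridin-2-yl ring would also match amino and methyl, and whether an amino group in place of the methyl of the 4-methylpyridin-3-yl group would keep the low number of compound 3.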